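This account rests on a few compounds, and the source may have more. Where it says the series, first, only, none or still open, it means among the compounds named here.

Compound 1 `CC(C)CS(=O)(=O)N1C[C@@H]2[C@H](C1)[C@@]2(CNC(=O)c1ccc(Cl)cc1Cl)CC1CC1` stands at the weak end of the three measured compounds in an assay on isolated protein for inhibition of sodium- and chloride-dependent glycine transporter 1 (Homo sapiens); a lower number here means a stronger inhibitor, a higher number a weaker inhibitor: compound 1 gives 2900 nM, whereas compound 2 `Cn1cnc(S(=O)(=O)N2C[C@@H]3[C@H](C2)[C@@]3(CNC(=O)c2cc(Cl)cc(Cl)c2)CC2CC2)c1` gives 100 nM and compound 3 `Cn1cnc(S(=O)(=O)N2C[C@@H]3[C@H](C2)[C@@]3(CNC(=O)c2ccccc2C(F)(F)F)CC2CC2)c1` gives 5 nM. Both of those differ from compound 1 in two places at once, in the sulfonyl group and in the ring on the carbonyl carbon, so their values cannot be tied to either change alone. For the measured compounds named here, the only single-place step among the measured compounds, a 20-fold lower number from compound 2 to compound 3 (1.30 log units; beyond the scatter), concerns the ring on the carbonyl carbon and says nothing about the sulfonyl side. Compound 4 `O=C(NC[C@]1(CC2CC2)[C@@H]2CN(S(=O)(=O)CC3CC3)C[C@@H]21)c1ccc(Cl)cc1Cl` keeps the core and the amide part of compound 1 and alters only the sulfonyl substituent: cyclopropyl in place of isopropyl on a saturated chain carbon bound to a sulfonyl sulfur. Going by the values given here, no measured pair shows what this kind of swap does, so there is no step to lean on. The step from compound 1 to compound 4 is therefore expected to be small, a 1.1-fold lower number from compound 1 to compound 4 (0.05 log units; within the scatter), with no direction favored. Compound 4 is estimated at 2600 nM, within a range from 800 nM to 8000 nM.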

Compound 4, half-maximal inhibitory concentration: 230 nM
Compound 4: the middle estimate sits 11-fold (1.05 log units) above what was measured; measured number below the stated range.
By their numbers in this assay, from the lowest: compound 3; then compound 2; then compound 4; then compound 1.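

In this assay the sulfonyl substituent turns out to matter: with the core and the amide part held fixed, cyclopropyl in place of isopropyl gives a 13-fold lower number from compound 1 to compound 4 (1.10 log units; beyond the scatter) on its own. For the compounds shown here, this is the first single-place step on the sulfonyl side, since the earlier step concerned only the ring on the carbonyl carbon. Both groups hold 3 heavy atoms, all carbon, and neither has a hydrogen-bond donor or acceptor, so the listed difference is the three-membered ring itself, and nothing shown gives a reason for the step.

On these data alone, whether the step carries over when the ring on the carbonyl carbon is that of compound 2 or compound 3 stays open. Also open, as far as these compounds go, is how a cyclobutyl group or a longer chain in that place would read in this assay as a test of how far this trend goes.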